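The source may hold more compounds than are shown below. What is called first, only, known or untested is meant among the compounds shown, and "the series" means these compounds.

Of the compounds shown here, two have been tested so far. Compound 1 `C=CCn1c(=O)/c(=C\c2cc(Br)ccc2F)[nH]c(=O)/c1=C\c1ccccc1OC` was examined in a functional assay on A549 cells (Homo sapiens) for cytotoxicity, read by CCK-8 assay, with a stated time of 72 h (a higher number here means a weaker inhibitor, a lower number a stronger inhibitor), and came back as "not active" (no number reported), with no number attached. Within the data shown here, compound 2 `C=CCn1c(=O)/c(=C\c2ccccc2C(F)(F)F)[nH]c(=O)/c1=C\c1ccccc1OC` gives 7000 nM in this assay, and since that is the only number known, compound 2 cannot be placed above or below any other compound. Compound 3 `C=CCn1c(=O)/c(=C\c2ccc(F)c(Br)c2)[nH]c(=O)/c1=C\c1ccccc1OC` carries 3-bromo-4-fluorophenyl in place of 2-(trifluoromethyl)phenyl on a double-bonded chain carbon bound to an aromatic carbon. The outlook for compound 3 rests on two things: compound 2 gives 7000 nM, and compound 1 was reported as "not active" (no number reported) despite also carrying a bromine and a fluorine on its ring. Among the measured compounds shown here, the step expected from compound 2 to compound 3 is therefore a 1.7-fold higher number from compound 2 to compound 3 (0.23 log units; within the scatter), towards a weaker inhibitor, though no measured step shows how large such a change is. Compound 3 is estimated to give 12000 nM in this assay, within a range from 5000 nM to 30000 nM, and a result with no number is quite possible.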

Compound 3, half-maximal inhibitory concentration: "not active" (no number reported)
The entry for compound 3 holds no number; no gap can be computed for the estimate.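

Among these compounds, compound 3 was reported without a number, so no step from compound 2 to compound 3 can be read. No measurement shown here offers an explanation for this result. The compounds shown leave open whether compound 1 and compound 3 differ from compound 2 by a little or by a lot.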